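The source may report more compounds than this note shows. Statements on the series, on what has been measured and on what is new or still open speak of the compounds shown alone.

Compound 2 `COC(=O)/C=C(\C)C[C@@H](OC(C)=O)[C@@]1(C)[C@H](C)CC=C2[C@@H]1CCCC2(C)C` in a functional assay on MCF7 cells (Homo sapiens) for cytotoxicity, read by MTT assay, with a stated time of 72 h (on this read-out lower numbers stand for stronger inhibition and higher numbers for weaker inhibition), gives > 30000 nM, which is a limit of the assay and not a number. Compound 1 `CC(=O)O[C@H](C/C(C)=C/CO)[C@@]1(C)[C@H](C)CC=C2[C@@H]1CCCC2(C)C` in this assay likewise gives > 30000 nM, also a limit. The step that the two limits leave unreadable from compound 1 to compound 2 cannot be read because of the limit of > 30000 nM in this assay, at which 2 of the 2 values shown sit. Compound 3 `CC(=O)O[C@H](C/C(C)=C/C(=O)O)[C@@]1(C)[C@H](C)CC=C2[C@@H]1CCCC2(C)C` differs from compound 2 by hydrogen in place of methyl on an oxygen next to a carbonyl group. No measured step matches this change, and the single step shown is unreadable, so no direction can be drawn from it. Compound 3 is expected to sit at 40000 nM, range 15000 nM to 120000 nM, most likely again returned as a limit. The estimated step is a step that the limit leaves unreadable from compound 2 to compound 3.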

Compound 3, half-maximal inhibitory concentration: > 30000 nM
Compound 3: a limit, no number (the forecaster's own chance of this, stated with the estimate: 85%); the middle value lies beyond the limit too.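

No step among compound 1, compound 2 and compound 3 can be read, because all three stop at one limit: the limit of > 30000 nM in this assay, at which 3 of the 3 values shown sit.

On these data alone, whether hydroxymethyl, methoxycarbonyl and carboxy differ at all in this read-out stays open.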